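Aryl amine variation on a shared core

The source may report more compounds than this note shows. Statements on the series, on what has been measured and on what is new or still open speak of the compounds shown alone.

Three analogues share one core and differ only in the aryl group on the amine nitrogen. Compound 1 `COc1cccc(NC2=CC(=O)c3c(nc4n3[C@H]3OC[C@@H](O)[C@H]3OC4)C2=O)c1` carries a methoxy on an aromatic carbon, and in a functional assay on MCF7 cells (Homo sapiens) for inhibition, read by sulforhodamine B assay (a higher number here means a weaker inhibitor, a lower number a stronger inhibitor), compound 1 gives 3830 nM. Among the compounds with values here, compound 3 `O=C1C(Nc2cccc(Cl)c2)=CC(=O)c2c1nc1n2[C@H]2OC[C@@H](O)[C@H]2OC1` carries chloro in its place; in this assay compound 3 gives 2970 nM, and the only single-site step measured so far, a 1.3-fold lower number from compound 1 to compound 3 (0.11 log units; within the scatter), stays within the scatter. Compound 2 `Cc1ccc(NC2=CC(=O)c3nc4n(c3C2=O)[C@H]2OC[C@@H](O)[C@H]2OC4)cc1C` carries the 3,4-dimethylphenyl group; in this assay compound 2 gives 2080 nM, the lowest of the three numbers, though both other compounds lie within the scatter of it, so no order can be read among the three.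

Compound 4 `O=C1C=C(Nc2ccccc2)C(=O)c2c1nc1n2[C@H]2OC[C@@H](O)[C@H]2OC1` is the unsubstituted member: phenyl in place of 3,4-dimethylphenyl on an amine nitrogen. Within the data shown here, no measured step removes a substituent from the aryl ring on the amine nitrogen, so nothing bears on this change directly; the one step available, between a methoxy and a chloro, was within the scatter, and all three aryl variants sit in a narrow band. The expectation is therefore no step beyond the scatter, the estimated step of a 1.4-fold higher number from compound 2 to compound 4 (0.16 log units; within the scatter) keeping compound 4 inside the band seen so far. Compound 4 is expected to give 3000 nM in this assay, within a range of 1400 nM to 6500 nM.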

Compound 4, half-maximal inhibitory concentration: > 4000 nM
Compound 4 was reported as a limit; the forecaster's own chance of this, stated with the estimate: 5%; at least 1.3-fold (0.12 log units) between middle value and limit.
By their numbers in this assay, from the lowest: compounds 2, 3 and 1 (each within the scatter of the next). At a limit, above all of these: compound 4.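

The reading for compound 4 in this assay is a limit of the assay and not a number: the limit of > 4000 nM in this assay, at which 1 of the 4 values shown sits.

Phenyl in place of 3,4-dimethylphenyl on the amine nitrogen gives an at least 1.9-fold higher number from compound 2 to compound 4 (0.28 log units; that floor lies within the scatter). Within the data shown here, only the lower bound of this step is known, so it is the first change at this position that could exceed the scatter, although its floor does not show that it does, and the earlier methoxy-to-chloro step offered no such possibility.

From the compounds shown here alone, the true value for compound 4 stays open, and with it whether the change from (3,4-dimethylphenyl)amino to anilino matters or leaves the reading within the scatter. Also open, going by these compounds, are whether a single methyl group on the phenyl ring would move the reading in this assay, and what an amine, a carboxylic acid or a longer alkyl chain would do in place of the aryl group on the amine nitrogen.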